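The source may hold more compounds than are shown below. What is called first, only, known or untested is meant among the compounds shown, and "the series" means these compounds.

Measured compounds in a functional assay on A549 cells (Homo sapiens) for inhibition, read by MTT assay, with a stated time of 24 h; a lower number here means a stronger inhibitor, a higher number a weaker inhibitor:
compound 1 `CCOC(=O)C1=Cc2ccccc2OC1(OCc1cc(-c2ccc3ccccc3c2)no1)C(F)(F)F` gives > 150000 nM, a limit of the assay.
compound 2 `CCOC(=O)C1=Cc2ccccc2OC1(OCc1cc(-c2ccc(Cl)cc2)no1)C(F)(F)F` gives 19100 nM.
compound 3 `CCOC(=O)C1=Cc2ccccc2OC1(OCc1cc(-c2ccc(Br)cc2)no1)C(F)(F)F` gives > 150000 nM, a limit of the assay.

Compound 3 stands at the limit (the limit of > 150000 nM in this assay, at which 2 of the 3 values shown sit), where compound 1 also sits, and compound 2 alone gives a number. The step of an at least 7.8-fold higher number from compound 2 to compound 3 (0.89 log units; beyond the scatter) is beyond the scatter. The step that the two limits leave unreadable from compound 1 to compound 3. The step of an at least 7.8-fold lower number from compound 1 to compound 2 (0.89 log units; beyond the scatter).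

Compound 4 `CCOC(=O)C1=Cc2ccccc2OC1(OCc1cc(-c2ccc(F)cc2)no1)C(F)(F)F` has not yet been measured. It differs from compound 3 by fluoro in place of bromo on an aromatic carbon. Of the measured steps only an at least 7.8-fold higher number from compound 2 to compound 3 (0.89 log units; beyond the scatter) bears on it. That step too exchanges one halogen for another on the same aromatic carbon; it shows that the size of the halogen at this place moves the number by at least a modest amount, with the smaller chloro giving the lower number. Whether fluoro continues this trend is not shown by compounds 1 to 3. Compound 4 is expected to give roughly 50000 nM in this assay, with a range from 8000 nM to 300000 nM. The expected step is an at least 3.0-fold lower number from compound 3 to compound 4 (0.47 log units; beyond the scatter), with a fair chance that only a limit is reported.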

Compound 4, half-maximal inhibitory concentration: 35500 nM
Beside the measured number, compound 4's estimate is 1.4-fold (0.15 log units) above it; the measured number falls inside the stated range.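

In this assay, fluoro in place of bromo on this aromatic carbon brings the number down from the limit of the assay, an at least 4.2-fold lower number from compound 3 to compound 4 (0.62 log units; beyond the scatter), and 4-fluorophenyl in place of naphthalen-2-yl does likewise, an at least 4.2-fold lower number from compound 1 to compound 4 (0.62 log units; beyond the scatter). Fluoro and chloro cannot be told apart here, a 1.9-fold higher number from compound 2 to compound 4 (0.27 log units; within the scatter), so the halogens do not form a graded series: the change seen with bromo is set against two halogens that read alike. Compound 1 and compound 3 remain limits, not numbers: the limit of > 150000 nM in this assay, at which 2 of the 4 values shown sit.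

As far as these compounds go, how an amine, a methoxy group or a carboxylic acid on this carbon would read remains open. No measured property is at hand to account for the gap between bromo and the other two halogens.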